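Series notes: the step from compound 3 to compound 4

A few compounds are considered here, and "the series" means these few. Any claim that something is new, unique, unknown or untested is made for them only; others in the source may bear on it.

Measured in an assay on HeLa cells for agonist activity at Bile acid receptor (Homo sapiens), read by a luciferase reporter, with a stated time of 24 h; on this read-out higher numbers stand for an effect only at larger amounts of compound and lower numbers for an effect already at smaller amounts:
- compound 1 `CS(=O)(=O)Nc1ccc(CNC(=O)c2ccc(C3(C(F)(F)F)CC3)cc2)c(Cl)c1`: 540 nM
- compound 2 `CS(=O)(=O)Nc1ccc(CNC(=O)c2ccc(N3CCC3)cc2)c(Cl)c1`: 13000 nM
- compound 3 `CCOc1ccc(C(=O)NCc2ccc(NS(C)(=O)=O)cc2Cl)cc1`: 2200 nM

Compound 3 holds the second highest of the three numbers. The step of a 4.1-fold higher number from compound 1 to compound 3 (0.61 log units; beyond the scatter) and the step of a 5.9-fold lower number from compound 2 to compound 3 (0.77 log units; beyond the scatter) place it between the other two, each gap beyond the scatter, with compound 1 giving the lowest number of the set.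

Compound 4 `CC(F)(F)c1ccc(C(=O)NCc2ccc(NS(C)(=O)=O)cc2Cl)cc1` differs from compound 3 in one place: 1,1-difluoroethyl in place of ethoxy on an aromatic carbon. The group that enters carries fluorine, as does the 1-(trifluoromethyl)cyclopropyl of compound 1; the group that leaves is the ethoxy of compound 3. The measured steps that bear on the change are a 4.1-fold higher number from compound 1 to compound 3 (0.61 log units; beyond the scatter) and a 5.9-fold lower number from compound 2 to compound 3 (0.77 log units; beyond the scatter): three groups at the same aromatic carbon span a wide range in this assay, and the fluorine-bearing one gave the lowest number. For the measured compounds named here, only one fluorine-bearing group has been measured, so a step toward compound 1 rather than compound 2 is expected, but smaller than the reverse of a 4.1-fold higher number from compound 1 to compound 3 (0.61 log units; beyond the scatter). The expected step is a 2.4-fold lower number from compound 3 to compound 4 (0.39 log units; beyond the scatter). Compound 4 is estimated at 900 nM, with a range from 300 nM to 2700 nM.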

Compound 4, half-maximal effective concentration: 1200 nM
For compound 4 the middle estimate is 1.3-fold (0.12 log units) below the measured one; measured number inside the range.
By their numbers in this assay, from the lowest: compound 1; then compounds 4 and 3 (each within the scatter of the next); then compound 2.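

In this assay, at this aromatic carbon para to a large group, 1,1-difluoroethyl in place of ethoxy gives (a 1.8-fold lower number from compound 3 to compound 4 (0.26 log units; within the scatter)), so this exchange does not separate the two groups, even though ethoxy counts one hydrogen-bond acceptor and 1,1-difluoroethyl none. Carrying fluorine does not by itself match compound 1, since the two fluorine-bearing groups remain apart (a 2.2-fold higher number from compound 1 to compound 4 (0.35 log units; beyond the scatter)), and compound 1 now stands alone at the low end of the series with a group that has a ring as well as fluorine. Azetidin-1-yl also remains clearly separate from the new group (an 11-fold lower number from compound 2 to compound 4 (1.03 log units; beyond the scatter)), which leaves compound 2 apart from both open-chain groups, ethoxy and 1,1-difluoroethyl.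

No data at hand account for any of these steps. Still open is whether the ring or the fluorine of compound 1 carries its lower number, which a plain cyclopropyl, a tert-butyl or a trifluoromethyl on the same carbon would help to settle, and whether a longer alkyl chain or a larger saturated amine such as piperidine would read differently from the groups shown.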